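Moving a hydroxyl on a pyridine-bridged biaryl phenol

The source may hold more compounds than are shown below. What is called first, only, known or untested is meant among the compounds shown, and "the series" means these compounds.

The set begins with compound 1 `Oc1ccc(-c2cc(-c3cccs3)cc(-c3ccccc3O)n2)cc1` and compound 2 `Oc1cccc(-c2cc(-c3ccccn3)cc(-c3ccccc3O)n2)c1`, both tested in a functional assay on DU-145 cells (Homo sapiens) for cytotoxicity, read by CCK-8 assay; a lower number here means a stronger inhibitor, a higher number a weaker inhibitor. For compound 1 the assay reports only a limit, > 50000 nM. Among the compounds with values here, compound 2 gives 17100 nM, the only actual number in this assay; the other entry is the limit of > 50000 nM in this assay, at which 1 of the 2 values shown sits. Compound 3 `Oc1ccc(-c2cc(-c3ccccn3)cc(-c3ccccc3O)n2)cc1` has not yet been measured. It differs from compound 2 in one place: 4-hydroxyphenyl in place of 3-hydroxyphenyl on an aromatic carbon. No step between two measured compounds is shown, so the size of this change cannot be read from the data. Compound 3 shares its 4-hydroxyphenyl group with compound 1, whose value in this assay is a limit, while compound 2 carries the 3-hydroxyphenyl and gives a number. On that basis compound 3 is expected to be a weaker inhibitor, with an expected step of a 1.9-fold higher number from compound 2 to compound 3 (0.27 log units; within the scatter). The estimate for compound 3 in this assay is 32000 nM, with an expected range from 12000 nM to 80000 nM.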

Compound 3, half-maximal inhibitory concentration: 25400 nM
Compound 3: the middle estimate sits 1.3-fold (0.10 log units) above what was measured, within the range that was stated.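

In this assay, 4-hydroxyphenyl in place of 3-hydroxyphenyl gives a 1.5-fold higher number from compound 2 to compound 3 (0.17 log units; within the scatter), so at this position, next to the ring nitrogen, the two hydroxyphenyl groups cannot be told apart. The set now also holds a step at the other position, where pyridin-2-yl in place of thiophen-2-yl gives an at least 1.9-fold lower number from compound 1 to compound 3 (0.29 log units; that floor lies within the scatter). The entry for compound 1 is a limit and not a number, so this step is only a floor: the limit of > 50000 nM in this assay, at which 1 of the 3 values shown sits.

The compounds shown leave open whether an amine or a carboxylic acid in place of the hydroxyl on this phenyl ring would shift the number beyond the scatter. All three compounds carry the 2-hydroxyphenyl group, so what that group contributes to these values cannot be read.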